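Two Measured Amides and an Unmeasured Third

A few compounds are considered here, and "the series" means these few. Any claim that something is new, unique, unknown or untested is made for them only; others in the source may bear on it.

Measured so far:
compound 1, `CCOC(=O)C1CCN(C(=O)CN2CN(c3ccccc3)C3(CCN(C(=O)c4ccc(C5CCCCC5)cc4)CC3)C2=O)CC1`: 900 nM
compound 2, `CCOC(=O)C1CCN(C(=O)CN2CN(c3ccccc3)C3(CCN(C(=O)c4ccc(C(C)(C)C)cc4)CC3)C2=O)CC1`: 3100 nM

In an assay on HEK293 cells for displacement of a labelled ligand from NPC1-like intracellular cholesterol transporter 1 (Homo sapiens) (a lower number here means a stronger inhibitor, a higher number a weaker inhibitor), compound 1 gives 900 nM, the lowest of the two numbers. Within the data shown here, its only neighbour is compound 2, which gives 3100 nM; the single measured step, a 3.4-fold higher number from compound 1 to compound 2 (0.54 log units; beyond the scatter), comes from tert-butyl in place of cyclohexyl on an aromatic carbon.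

Compound 3, `O=C(CN1CN(c2ccccc2)C2(CCN(C(=O)c3ccc(C4CCCCC4)cc3)CC2)C1=O)NCCCCO`, keeps the cyclohexyl of compound 1 and changes the other end of the molecule: (4-hydroxybutyl)amino in place of 4-(ethoxycarbonyl)piperidin-1-yl on a carbonyl carbon. Among the measured compounds shown here, no measured step touches that carbonyl carbon, so nothing in the two numbers bears directly on this change; the cyclohexyl step concerns a different part of the shared core. The expectation for compound 3 therefore rests on compound 1 alone and stays wide: its number is estimated at 1500 nM, between 400 nM and 6000 nM. The expected step is a 1.7-fold higher number from compound 1 to compound 3 (0.22 log units; within the scatter), which may well be no more than the scatter.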

Compound 3, half-maximal inhibitory concentration: 10300 nM
The estimate for compound 3 lay 6.9-fold (0.84 log units) below the measured number; the whole stated range lies below it.
By their numbers in this assay, from the lowest: compound 1; then compound 2; then compound 3.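

In this assay, the group on this carbonyl carbon proves to matter: the change brings an 11-fold higher number from compound 1 to compound 3 (1.06 log units; beyond the scatter), which compounds 1 and 2 could not show, since both carry 4-(ethoxycarbonyl)piperidin-1-yl. The swap replaces a group of 11 heavy atoms, with a six-membered ring and no hydrogen-bond donors, by an open chain of 6 heavy atoms with 2 hydrogen-bond donors, so several features change at once and this single step cannot separate them. Nothing available accounts for the size of this step.

From the compounds shown here alone, it remains open whether the ring, the ester or the terminal hydroxyl decides the outcome; plain piperidin-1-yl, 4-carboxypiperidin-1-yl and butylamino would each bear on that question. Going by these compounds, it is also open whether the step would be of similar size with tert-butyl in place of cyclohexyl.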